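A few compounds are considered here, and "the series" means these few. Any claim that something is new, unique, unknown or untested is made for them only; others in the source may bear on it.

In a functional assay on MCF7 cells (Homo sapiens) for inhibition, read by resazurin assay, with a stated time of 72 h (on this read-out higher numbers stand for weaker inhibition and lower numbers for stronger inhibition), compound 1 `COc1ccc(C2C(O)C(=O)N2c2cc(OC)c(OC)c(OC)c2)cc1` gives 4 nM, compound 2 `CCSc1ccc(C2C(O)C(=O)N2c2cc(OC)c(OC)c(OC)c2)cc1` gives 6 nM and compound 3 `C=CC1C(=O)N(c2cc(OC)c(OC)c(OC)c2)C1c1ccc(SC)cc1` gives 51 nM. Compound 2 thus sits level with compound 1 and well under compound 3 among these three numbers. The step followed here leads to compound 4 `C=CC1C(=O)N(c2cc(OC)c(OC)c(OC)c2)C1c1ccc(SCC)cc1`, with vinyl in place of hydroxy on a saturated ring carbon of the four-membered non-aromatic ring: vinyl in place of hydroxy on a saturated ring carbon. For the measured compounds named here, no measured step covers this exchange directly. Going by the values given here, the only measured step, a 1.5-fold higher number from compound 1 to compound 2 (0.18 log units; within the scatter), concerns ethylsulfanyl in place of methoxy on an aromatic carbon, so the ethylsulfanyl group is not expected to shift the number much by itself. Of the measured compounds, only compound 3 carries vinyl, and compound 3 gives 51 nM. Compound 4 is therefore expected near that value in this assay, on the side of weaker inhibition relative to compound 2. The expected change is an 8.3-fold higher number from compound 2 to compound 4 (0.92 log units; beyond the scatter). For compound 4 the estimated value is 50 nM, with an expected range of 20 nM to 125 nM.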

Compound 4, half-maximal inhibitory concentration: 181 nM
The estimate for compound 4 lay 3.6-fold (0.56 log units) below the measured number, outside the stated range (above it).
By their numbers in this assay, from the lowest: compounds 1 and 2 (each within the scatter of the next); then compound 3; then compound 4.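

In this assay, the exchange at the saturated ring carbon of the four-membered non-aromatic ring proves costly, with vinyl in place of hydroxy next to the ring atom that bears a 4-(ethylsulfanyl)phenyl group giving a 30-fold higher number from compound 2 to compound 4 (1.48 log units; beyond the scatter). With vinyl on that carbon, the sulfur chain also counts: methyl in place of hydrogen on the saturated chain carbon bound to the sulfur gives a 3.5-fold higher number from compound 3 to compound 4 (0.55 log units; beyond the scatter), whereas the different exchange in the hydroxy series, ethylsulfanyl in place of methoxy, gives a 1.5-fold higher number from compound 1 to compound 2 (0.18 log units; within the scatter). Nothing given here accounts for either step.

On these data alone, it remains open whether an amine, a methyl group or a fluorine on that ring carbon would behave like hydroxy or like vinyl. Also open, as far as these compounds go, is how a longer chain on the sulfur, such as propyl, would read alongside vinyl or hydroxy.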